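This account rests on a few compounds, and the source may have more. Where it says the series, first, only, none or still open, it means among the compounds named here.

Of the compounds shown here, three built on one shared core have been tested for cytotoxicity. In a functional assay on HL-60 cells (Homo sapiens) for cytotoxicity, read by luminescence and CellTiter-Glo, with a stated time of 3 days (on this read-out higher numbers stand for weaker inhibition and lower numbers for stronger inhibition), compound 1 `N#Cc1ccc(NC(=O)c2ccc(Br)cc2O)cc1` gives 1210 nM. In this assay compound 2 `N#Cc1ccc(NC(=O)c2ccc(C(F)(F)F)cc2O)cc1` gives 1030 nM, and the change a 1.2-fold lower number from compound 1 to compound 2 (0.07 log units; within the scatter) shows nothing beyond the scatter. In this assay compound 3 `Cc1cccc(O)c1C(=O)Nc1ccc(C#N)cc1` gives 6860 nM, the highest of the three numbers, standing beyond the scatter from both compound 1 and compound 2.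

Compound 4 `N#Cc1ccc(NC(=O)c2ccccc2O)cc1` differs from compound 3 by a single change: hydrogen in place of methyl on an aromatic carbon. Among the compounds with values here, no measured step covers this change directly; the one measured step, a 1.2-fold lower number from compound 1 to compound 2 (0.07 log units; within the scatter), concerns a different position and lies within the scatter. Compound 1 and compound 2 both lack the methyl yet each carry another group elsewhere, so their much lower numbers cannot be assigned to the methyl alone. Compound 4 is therefore expected to give roughly 2500 nM, with a wide range from 800 nM to 8000 nM. That estimate means a step of a 2.7-fold lower number from compound 3 to compound 4 (0.44 log units; beyond the scatter), a drop toward the level of compound 1 and compound 2 but with little certainty.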

Compound 4, half-maximal inhibitory concentration: 4620 nM
Estimate against measurement, compound 4: 1.8-fold (0.27 log units) below; the measured number falls inside the stated range.
By their numbers in this assay, from the lowest: compounds 2 and 1 (each within the scatter of the next); then compounds 4 and 3 (each within the scatter of the next).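

In this assay, hydrogen in place of methyl gives a 1.5-fold lower number from compound 3 to compound 4 (0.17 log units; within the scatter) and so the methyl on this aromatic carbon, ortho to a large group, makes no readable difference. Compared with compound 4, the other two compounds tell a different story: hydrogen in place of trifluoromethyl gives a 4.5-fold higher number from compound 2 to compound 4 (0.65 log units; beyond the scatter) and hydrogen in place of bromo gives a 3.8-fold higher number from compound 1 to compound 4 (0.58 log units; beyond the scatter) at their own position, so the lower numbers of compound 1 and compound 2 go with those two groups and not with the absence of the methyl. Nothing measured here explains these differences.

As far as these compounds go, it remains open whether an amine or a methoxy group on the methyl-bearing carbon would move the number. From the compounds shown here alone, it is also open whether bromo or trifluoromethyl on that carbon would match the modest steps seen at their own position.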